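Shortening the Chain Once More in Rat Dosing

This account rests on a few compounds, and the source may have more. Where it says the series, first, only, none or still open, it means among the compounds named here.

Two compounds share one core and differ only in the length of a saturated chain attached to it. Compound 1 `CCCCc1cc(O)cc(=O)n1Cc1ccc(-c2ccccc2-c2nn[nH]n2)cc1` carries a butyl chain, compound 2 `CCCc1cc(O)cc(=O)n1Cc1ccc(-c2ccccc2-c2nn[nH]n2)cc1` a propyl chain. Going by the values given here, in a functional assay on the whole organism with Rattus norvegicus as the target (on this read-out lower numbers stand for an effect already at smaller amounts and higher numbers for an effect only at larger amounts of compound), compound 1 gives 0.38 mg/kg, while compound 2 gives 0.048 mg/kg, the lower of the two numbers measured so far. Among the compounds with values here, the single measured step, a 7.9-fold lower number from compound 1 to compound 2 (0.90 log units; beyond the scatter), is the only comparison available.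

Compound 3 `CCc1cc(O)cc(=O)n1Cc1ccc(-c2ccccc2-c2nn[nH]n2)cc1` has not yet been tested. It differs from compound 2 in one place: hydrogen in place of methyl on a saturated chain carbon, two bonds along the chain from an aromatic carbon, so the propyl chain of compound 2 becomes an ethyl chain. Within the data shown here, the one step that bears on this change is the earlier trimming of the same chain by one carbon, which went clearly beyond the scatter toward a lower number. Whether a second cut behaves the same way cannot be known from a single step, so the expectation is cautious: either a further modest drop or no step beyond the scatter. For compound 3 in this assay the estimate is 0.04 mg/kg, with a range from 0.012 mg/kg to 0.14 mg/kg. That figure corresponds to an expected step of a 1.2-fold lower number from compound 2 to compound 3 (0.08 log units; within the scatter).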

Compound 3, dose for 50% inhibition: 0.084 mg/kg
Estimate against measurement, compound 3: 2.1-fold (0.32 log units) below; low and high end bracket the measured number.
By their numbers in this assay, from the lowest: compounds 2 and 3 (each within the scatter of the next); then compound 1.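

In this assay, taking one more carbon off the chain, propyl to ethyl, gives a 1.8-fold higher number from compound 2 to compound 3 (0.24 log units; within the scatter) and so does not separate the two compounds, whereas the earlier cut from butyl to propyl did go beyond the scatter. Going straight from the butyl chain to the ethyl chain gives a 4.5-fold lower number from compound 1 to compound 3 (0.66 log units; beyond the scatter) and still clears the scatter, so among these three compounds the butyl chain stands apart while the propyl and ethyl chains sit together, and the gain from trimming this chain does not carry on with each carbon removed. Nothing measured here explains why the chain behaves this way.

The compounds shown leave open whether a methyl in place of the ethyl chain would stay level with compound 3 or move clearly away from it, and whether a longer chain such as pentyl would push the number further up than in compound 1. Also open, from the compounds shown here alone, is how this position would respond to something other than a plain straight chain, such as an isopropyl group or an amine at the end of the chain.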